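The source may report more compounds than this note shows. Statements on the series, on what has been measured and on what is new or still open speak of the compounds shown alone.

Within the data shown here, compound 2, `O=c1cnn(COC(CO)CO)c(=O)[nH]1`, belongs to a small set in which every number so far is a limit of the assay. In a functional assay on HepG2 cells (Homo sapiens) for cytotoxicity (on this read-out higher numbers stand for lower toxicity in this test and lower numbers for higher toxicity in this test), compound 2 gives > 460000 nM, a limit rather than a measured number. Its companion compound 1, `O=c1ccn(COC(CO)CO)c(=O)[nH]1`, is described by > 462000 nM in this assay, again a limit. Where compound 2 stands is therefore stated only as the limit of > 460000 nM in this assay, at which 1 of the 2 values shown sits, and compound 1 likewise sits at the limit of > 462000 nM in this assay, at which 1 of the 2 values shown sits; no step between the two can be measured. Compound 3, `Cc1nn(COC(CO)CO)c(=O)[nH]c1=O`, differs from compound 2 by methyl in place of hydrogen on an aromatic carbon. Since both measured values sit at a limit, no change beyond the scatter is expected in this assay, and the step from compound 2 to compound 3 is estimated as a number no higher from compound 2 to compound 3 (the limit leaves the size open). For compound 3 the expected value is 460000 nM, with a range from 200000 nM to 1000000 nM, and most likely the assay will again report only a limit.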

Compound 3, half-maximal cytotoxic concentration: > 432000 nM
Compound 3: a limit, no number; the forecaster's own chance of this, stated with the estimate: 85%; the middle value lies beyond the limit too.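

No step can be read between compound 2 and compound 3, whose results are both limits and not numbers. The compounds shown leave open whether methyl in place of hydrogen on an aromatic carbon changes the result in this assay at all, and where the true values of all three compounds lie.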